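Lengthening a Short Chain on Two Related Cores

A few compounds are considered here, and "the series" means these few. Any claim that something is new, unique, unknown or untested is made for them only; others in the source may bear on it.

Compound 1 `CCc1ccc(-c2cc(Cl)cc(C(=O)Nc3nn[nH]n3)n2)cc1` gives 100% in a functional assay on the whole organism with Rattus norvegicus as the target, at a dose of 3 mg/kg by the oral route; on this read-out lower numbers stand for a weaker effect and higher numbers for a stronger effect at the one dose given. Compound 2 `CCCCc1ccc(-c2cc(Cl)cc(C(=O)Nc3nn[nH]n3)n2)cc1` gives 83%. Compound 3 `COc1cc(C(=O)Nc2nn[nH]n2)nc(-c2ccccc2)c1` gives 97%.

The step from compound 1 to compound 2 is ethyl in place of hydrogen on a saturated chain carbon, two bonds along the chain from an aromatic carbon, and in this assay it reads a number 17 percentage points lower from compound 1 to compound 2 (beyond the scatter). Compound 4 `CCCOc1cc(C(=O)Nc2nn[nH]n2)nc(-c2ccccc2)c1` is not yet measured; it differs from compound 3 by ethyl in place of hydrogen on a saturated chain carbon bound to an oxygen on an aromatic ring. For the measured compounds named here, this is the same kind of change as the one from compound 1 to compound 2, but not the same: there the entering ethyl sits on a saturated chain carbon two bonds along the chain from an aromatic carbon, whereas here it sits on a saturated chain carbon bound to an oxygen on an aromatic ring. The difference between the core of compound 1 and the core of compound 3 is not broken down here. Because the earlier step of a number 17 percentage points lower from compound 1 to compound 2 (beyond the scatter) was modest and beyond the scatter, a step of similar direction and size is expected for compound 4, namely a number 12 percentage points lower from compound 3 to compound 4 (beyond the scatter). Compound 4 is therefore estimated at 85%, expected between 65% and 100%.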

Compound 4, a percentage reported as inhibition, in the whole organism at one dose (the size of the read-out at that dose, not a potency): 100%
Estimate against measurement, compound 4: 15 percentage points below; measured number inside the range.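

In this assay the new step reads a number 3 percentage points higher from compound 3 to compound 4 (within the scatter) and so stays within the usual scatter, while the same kind of change lowered the read-out on the core of compound 1. Set side by side, the two steps disagree: the same change on two cores in this assay, a number 17 percentage points lower (beyond the scatter) from compound 1 to compound 2 and a number 3 percentage points higher (within the scatter) from compound 3 to compound 4, 20 percentage points apart, beyond the scatter of two such steps. Among these four compounds, then, the result of adding ethyl on one core does not predict the result on the other, but this does not show why, since the two steps differ in where the ethyl sits as well as in the core, and each read-out gives the size of the effect at one dose rather than a potency.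

The compounds shown leave open whether a longer chain such as butoxy, or an amine or a carboxylic acid in the same place, would hold the read-out on the core of compound 3. For the compounds shown here, they also leave open how much of the disagreement belongs to the core alone, as no pair here carries the same chain in the same place on both cores.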